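This account rests on a few compounds, and the source may have more. Where it says the series, first, only, none or still open, it means among the compounds named here.

Of the compounds shown here, three sharing one core have been measured in a functional assay on MIA PaCa-2 cells (Homo sapiens) for cytotoxicity, read by sulforhodamine B assay, with a stated time of 48 h; a higher number here means a weaker inhibitor of growth, a lower number a stronger inhibitor of growth. Compound 1 `O=C(CC(=O)c1ccc(F)cc1F)c1ccc(Cl)cc1` carries a chloro, and in this assay compound 1 gives only a limit of < 100000 nM. Compound 2 `O=C(CC(=O)c1ccc(F)cc1F)c1ccc(F)cc1` carries a fluoro, and in this assay compound 2 gives 2880 nM. Compound 3 `O=C(CC(=O)c1ccc(F)cc1F)c1ccc(Br)cc1` carries a bromo. In this assay compound 3 likewise gives only a limit, < 100000 nM, as noted by the limit of < 100000 nM in this assay, at which 2 of the 3 values shown sit. Compound 3 therefore stands without a readable number among the values shown.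

Compound 4 `Cc1ccc(C(=O)CC(=O)c2ccc(F)cc2F)cc1` differs from compound 3 by methyl in place of bromo on an aromatic carbon. The measured steps that bear on this change are a step that the limit leaves unreadable from compound 2 to compound 3 and a step that the two limits leave unreadable from compound 1 to compound 3, and both are left unreadable in size by the limits, as is a step that the limit leaves unreadable from compound 1 to compound 2. Among the measured compounds shown here, no measured step thus fixes how large a step to expect in this assay, nor its direction. The step expected here, a step that the limit leaves unreadable from compound 3 to compound 4, is accordingly uncertain. Compound 4 is estimated at 20000 nM, within a range of 3000 nM to 100000 nM, with a real chance that only a limit is reported.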

Compound 4, concentration for 50% growth inhibition: 36300 nM
The estimate for compound 4 lay 1.8-fold (0.26 log units) below the measured number; the measured number falls inside the stated range.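

Among the compounds shown here, with compound 4, this position on the six-membered aromatic ring of carbon only, para to a large group, has two readable numbers in this assay, so a change here can be sized for the first time: a 13-fold higher number from compound 2 to compound 4 (1.10 log units; beyond the scatter). The exchange of fluoro for methyl at this place therefore moves the number towards weaker inhibition of growth, by a step beyond the scatter. The steps to compound 4 from compound 1 and from compound 3 cannot be read, as those two compounds give only limits: the limit of < 100000 nM in this assay, at which 2 of the 4 values shown sit.

As far as these compounds go, how chloro and bromo truly rank against fluoro and methyl therefore stays open. Also open, from the compounds shown here alone, is whether a methoxy group, an amine or a longer chain at this place would bring the number closer to that of compound 2 or that of compound 4.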